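The compounds below may be only part of what the source reports. "The series", "measured", "known", "first", "only" and "open" are said of these compounds alone.

Measured in a functional assay on MCF cells (Homo sapiens) for antiproliferative activity, with a stated time of 72 h; a higher number here means a weaker inhibitor, a lower number a stronger inhibitor:

Compound 1 `OC[C@H]1O[C@@H](n2cnc3c(NCc4ccccc4F)ncnc32)[C@H](O)[C@@H]1O`: > 166000 nM
Compound 2 `OC[C@H]1O[C@@H](n2cnc3c(NCc4ccccc4Cl)ncnc32)[C@H](O)[C@@H]1O`: > 166000 nM
Compound 3 `OC[C@H]1O[C@@H](n2cnc3c(NCc4ccc(Cl)cc4)ncnc32)[C@H](O)[C@@H]1O`: > 166000 nM

Each of these entries is a limit of the assay and not a number. Compound 3 stands at the limit of > 166000 nM in this assay, at which 3 of the 3 values shown sit. Going by the values given here, it therefore has no number of its own, and no compound here can be ranked against another.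

The next compound, compound 4 `OC[C@H]1O[C@@H](n2cnc3c(NCc4ccc(Br)cc4)ncnc32)[C@H](O)[C@@H]1O`, differs from compound 3 in one atom: bromo in place of chloro on an aromatic carbon. Put simply, this is bromo in place of chloro on an aromatic carbon, para to a large group.

The closest measured change is chloro in place of fluoro on an aromatic carbon, which is a step that the two limits leave unreadable from compound 1 to compound 2. Swapping 2-chlorophenyl for 4-chlorophenyl is a step that the two limits leave unreadable from compound 2 to compound 3. Swapping 2-fluorophenyl for 4-chlorophenyl is a step that the two limits leave unreadable from compound 1 to compound 3. None of these three steps has a readable size, so none offers a direction to carry over to this assay.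

No step beyond the usual scatter is expected here, and a report of the same limit is the likeliest outcome. The estimated change is a step that the limit leaves unreadable from compound 3 to compound 4. Compound 4 is expected to land near 170000 nM, with an estimated range of 70000 nM to 300000 nM.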

Compound 4, half-maximal inhibitory concentration: > 166000 nM
Compound 4: only a limit was reported; the forecaster's own chance of this, stated with the estimate: 80%; the middle value is on the limit's open side.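

In this assay compound 4 gives > 166000 nM, which is a limit and not a number. Going by these compounds alone, no step among compound 1, compound 2, compound 3 and compound 4 can be read, since all share one result: the limit of > 166000 nM in this assay, at which 4 of the 4 values shown sit. The compounds shown leave open how strongly any of them acts and whether changing the halogen alters that.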